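Pyrrolidin-1-yl for diisopropylamino: three measured, one expected

The compounds below may be only part of what the source reports. "The series", "measured", "known", "first", "only" and "open" are said of these compounds alone.

Three compounds in the series have been run through a functional assay on HEp-2 cells (Homo sapiens) for antiproliferative activity, read by MTT assay, with a stated time of 72 h; a higher number here means a weaker inhibitor, a lower number a stronger inhibitor. Compound 3 `CC(C)N(C(=S)SCc1cc(=O)c2ccc(Cl)cc2o1)C(C)C` gives 22700 nM. Compound 2 `CC(C)N(C(=S)SCc1oc2ccccc2c(=O)c1Cl)C(C)C` gives 20000 nM; its number and that of compound 3 lie within the scatter of each other, so no order between the two is claimed. Compound 1 `O=c1cc(CSC(=S)N2CCCC2)oc2cc(Cl)ccc12` returns a limit of the assay, > 40000 nM, and not a number. That limit is the evidence available on this step: the limit of > 40000 nM in this assay, at which 1 of the 3 values shown sits.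

Compound 1 differs from compound 3 by pyrrolidin-1-yl in place of diisopropylamino on a thiocarbonyl carbon. In this assay this gives an at least 1.7-fold higher number from compound 3 to compound 1 (0.24 log units; that floor lies within the scatter); its floor lies within the scatter, so the true size of the step is open upward.

Compound 4 `O=c1c(Cl)c(CSC(=S)N2CCCC2)oc2ccccc12` has not yet been measured. It differs from compound 2 by pyrrolidin-1-yl in place of diisopropylamino on a thiocarbonyl carbon, the same change at the same place as that from compound 3 to compound 1. The difference between the core of compound 2 and the core of compound 3 is not broken down here.

For the measured compounds named here, for compound 4 in this assay the expected step is a 1.9-fold higher number from compound 2 to compound 4 (0.28 log units; within the scatter), a step of about the size seen from compound 3 to compound 1, because the measured step of an at least 1.7-fold higher number from compound 3 to compound 1 (0.24 log units; that floor lies within the scatter) is the only guide to this change. Given the limit returned by compound 1, compound 4 may itself end at a limit rather than a number. The estimate for compound 4 is 38000 nM, expected to fall between 18000 nM and 90000 nM.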

Compound 4, half-maximal inhibitory concentration: 600 nM
Beside the measured number, compound 4's estimate is 63-fold (1.80 log units) above it; measured number outside the range, below it.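

In this assay, pyrrolidin-1-yl in place of diisopropylamino on a thiocarbonyl carbon gives a 33-fold lower number from compound 2 to compound 4 (1.52 log units; beyond the scatter), so this change does not carry from one core to the other as a fixed step, and the two cores do not share its size or its direction: the same change on two cores in this assay, an at least 1.7-fold higher number (0.24 log units; that floor lies within the scatter) from compound 3 to compound 1 and a 33-fold lower number (1.52 log units; beyond the scatter) from compound 2 to compound 4, at least 58-fold (1.76 log units) apart, beyond the scatter of two such steps

Compound 1 returns a limit and not a number, so the step on its core has only a floor and its true size stays open: the limit of > 40000 nM in this assay, at which 1 of the 4 values shown sits.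

The result shows that the outcome of this change depends on the core in these two pairs, but it does not show which feature of the core matters, since the difference between the core of compound 2 and the core of compound 3 is not broken down, and two pairs set no rule for other cores in the series.

Going by these compounds, what stays open is whether the low number of compound 4 belongs to pyrrolidin-1-yl specifically or would also appear with another cyclic amine on the thiocarbonyl carbon, such as piperidin-1-yl or morpholin-4-yl. Also open, on these data alone, is whether a simple acyclic amine such as diethylamino would follow compound 2 or compound 4 on that core in this assay.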